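This account rests on a few compounds, and the source may have more. Where it says the series, first, only, none or still open, it means among the compounds named here.

Series notes. In a functional assay on MCF7 cells (Homo sapiens) for inhibition, read by sulforhodamine B assay (on this read-out higher numbers stand for weaker inhibition and lower numbers for stronger inhibition), compound 1 `Cc1ccc(NC2=CC(=O)c3nc4n(c3C2=O)[C@H]2OC[C@@H](O)[C@H]2OC4)cc1` gives 1660 nM. Compound 3 `CCOc1ccc(NC2=CC(=O)c3nc4n(c3C2=O)[C@H]2OC[C@@H](O)[C@H]2OC4)cc1` carries ethoxy in place of methyl on an aromatic carbon and gives 1430 nM in this assay. Among the compounds with values here, the step of a 1.2-fold lower number from compound 1 to compound 3 (0.06 log units; within the scatter) is the only paired comparison in which both ends carry a number. Compound 2 `O=C1C(N2CCCCC2)=CC(=O)c2c1nc1n2[C@H]2OC[C@@H](O)[C@H]2OC1` is the member without one: in this assay compound 2 returns > 8000 nM, which is a limit of the assay and not a measured value. Compound 2 therefore sits at the limit of > 8000 nM in this assay, at which 1 of the 3 values shown sits, and nothing more precise can be said of where it stands.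

Compound 4 `CCCN(CCC)C1=CC(=O)c2c(nc3n2[C@H]2OC[C@@H](O)[C@H]2OC3)C1=O` is the next member due in this assay. Against compound 2 the change is dipropylamino in place of piperidin-1-yl on a double-bonded ring carbon. Within the data shown here, no measured step covers an exchange of one dialkylamino group for another. Among the measured compounds shown here, the single step on record, a 1.2-fold lower number from compound 1 to compound 3 (0.06 log units; within the scatter), lies elsewhere and is within the scatter, so it lends no direction to this exchange. With compound 2 already at the limit, no step beyond the scatter is expected from this change. The expected step is a step that the limit leaves unreadable from compound 2 to compound 4. Compound 4 is estimated at 10000 nM in this assay, within 4000 nM to 25000 nM, with a real chance that only a limit is reported again.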

Compound 4, half-maximal inhibitory concentration: > 16000 nM
Compound 4 was reported as a limit; the forecaster's own chance of this, stated with the estimate: 70%; middle value at least 1.6-fold (0.20 log units) from the limit.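

In this assay compound 2 and compound 4 both return only limits of the assay, and no step can be read between them. The compounds shown leave open whether dipropylamino and piperidin-1-yl differ at all in this assay, and how far compound 2 and compound 4 lie from compound 1 and compound 3.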